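Methoxy removal on an aromatic carbon of the shared core

This account rests on a few compounds, and the source may have more. Where it says the series, first, only, none or still open, it means among the compounds named here.

Measured compounds:
- compound 1, `COc1cccc2c1C(=O)C(C)(C)CO2`: 12.1%
- compound 2, `C#CCN(Cc1ccccc1)C1c2cccc(OC)c2OCC1(C)C`: 4.3%
- compound 3, `CC1(C)COc2ccccc2C1=O`: 9.7%

In an assay on BTI cells for inhibition of Amine oxidase [flavin-containing] A (Homo sapiens), read by fluorescence, with a stated time of 20 min, tested at 1 uM (a higher number here means more inhibition at the concentration tested (going by the name of the read-out), a lower number less inhibition), compound 1 gives 12.1%, compound 3 gives 9.7% and compound 2 gives 4.3%. All three numbers sit within the scatter of one another, so no order among them can be read. The change from compound 1 to compound 3 is hydrogen in place of methoxy on an aromatic carbon, and its step was a number 2.4 percentage points lower from compound 1 to compound 3 (within the scatter). The difference between the core of compound 1 and the core of compound 2 is not broken down here.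

Compound 4, `C#CCN(Cc1ccccc1)C1c2ccccc2OCC1(C)C`, is not yet measured. It differs from compound 2 by hydrogen in place of methoxy on an aromatic carbon, the same change as from compound 1 to compound 3, with the place lines identical. Because a number 2.4 percentage points lower from compound 1 to compound 3 (within the scatter) lay within the scatter, a step of about a number 1.3 percentage points lower from compound 2 to compound 4 (within the scatter) is expected from compound 2 to compound 4 in this assay. Compound 4 is therefore estimated at 3%, with a range from -6% to 12%.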

Compound 4, a percentage reported as inhibition, at one concentration (the size of the read-out at that concentration, not a potency): -10.6%
Compound 4: the middle estimate sits 13.6 percentage points above what was measured, and the stated range ends above it.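

In this assay, hydrogen in place of methoxy on an aromatic carbon now gives a number 14.9 percentage points lower from compound 2 to compound 4 (beyond the scatter), and this step can be set beside the earlier one: the same change on two cores in this assay, a number 2.4 percentage points lower (within the scatter) from compound 1 to compound 3 and a number 14.9 percentage points lower (beyond the scatter) from compound 2 to compound 4, 12.5 percentage points apart, within the scatter of two such steps. The two steps cannot be told apart, so the change may carry from one core to the other, but equal size on both cores is not established. Two pairs tested at one concentration show nothing about this change on any other core.

From the compounds shown here alone, it remains open whether a hydroxyl group or a chlorine atom on that aromatic carbon would shift the reading on the core of compound 2. Going by these compounds, the effect of an ethoxy group there is also open.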